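This account rests on a few compounds, and the source may have more. Where it says the series, first, only, none or still open, it means among the compounds named here.

Measured compounds:
compound 1 `N#Cc1ccc(CNc2cc(Br)cc3[nH]ncc23)cc1` gives 70%
compound 2 `CC(Nc1cc(Br)cc2[nH]ncc12)c1ccccc1` gives 14%
compound 3 `Oc1ccc(CNc2cc(Br)cc3[nH]ncc23)c(O)c1` gives 40%

In an assay for inhibition of Indoleamine 2,3-dioxygenase 1 (Homo sapiens), with a stated time of 1 h, tested at 10 uM (on this read-out higher numbers stand for more inhibition at the one concentration tested (going by the name of the read-out) and lower numbers for less inhibition), compound 3 stands second highest of the three numbers. Its nearest neighbour is compound 2, which lies lower by a gap beyond the usual scatter, and its furthest is compound 1, which lies higher by a gap also beyond the scatter. Compound 4 `Cc1cc(O)ccc1CNc1cc(Br)cc2[nH]ncc12` has not yet been measured in this assay. It differs from compound 3 in a single place: methyl in place of hydroxy on an aromatic carbon. The methyl sits ortho to a large group and meta to a hydroxy group. Among the measured compounds shown here, no pair among the measured compounds isolates this exchange, so the size of the step cannot be read from them; it can only be judged from where compound 3 stands. Compound 4 is therefore expected to remain close to compound 3, with a step of a number 2 percentage points lower from compound 3 to compound 4 (within the scatter) that is estimated to fall within the scatter. Compound 4 is expected to give 38%, with a range from 15% to 62%.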

Compound 4, a percentage reported as inhibition, at one concentration (the size of the read-out at that concentration, not a potency): 60%
Compound 4: middle estimate off by 22 percentage points, on the low side; low and high end bracket the measured number.
By their numbers in this assay, from the lowest: compound 2; then compound 3; then compounds 4 and 1 (each within the scatter of the next).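

In this assay the number moves a number 20 percentage points higher from compound 3 to compound 4 (beyond the scatter) when methyl replaces hydroxy on this aromatic carbon, ortho to a large group and meta to a hydroxy group, so this position is not indifferent to what sits on it. A hydroxy group is not required at this place for inhibition on this read-out, and methyl, which counts no hydrogen-bond donor or acceptor, serves better here. Nothing available explains why the number rises with this exchange.

From the compounds shown here alone, it remains open whether methoxy, ethyl or a chlorine atom at this place would give a number like that of methyl or a different one. Going by these compounds, it is also open what the remaining hydroxy group contributes, and whether an amine or a hydrogen in its stead would change the read-out.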